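Ring Enlargement on the Triazole Side Chain

A few compounds are considered here, and "the series" means these few. Any claim that something is new, unique, unknown or untested is made for them only; others in the source may bear on it.

Compound 1 `CCCCc1cn(-c2nc(NC)c3ncn([C@@H]4O[C@H](CO)[C@@H](O)[C@H]4O)c3n2)nn1` gives 848 nM in an assay on CHO cells for displacement of a labelled ligand from adenosine receptor A1 (Homo sapiens); a lower number here means a stronger inhibitor, a higher number a weaker inhibitor. Among the measured compounds shown here, compound 2 `CNc1nc(-n2cc(CC3CCCC3)nn2)nc2c1ncn2[C@@H]1O[C@H](CO)[C@@H](O)[C@H]1O` gives 335 nM in this assay, the lowest of the two numbers known, with a 2.5-fold lower number from compound 1 to compound 2 (0.40 log units; beyond the scatter) as the one step available. Compound 3 `CNc1nc(-n2cc(CC3CCCCC3)nn2)nc2c1ncn2[C@@H]1O[C@H](CO)[C@@H](O)[C@H]1O` differs from compound 2 by cyclohexyl in place of cyclopentyl on a saturated chain carbon bound to an aromatic carbon. For the measured compounds named here, only that single modest step bears on this change, and it points downward. On this basis compound 3 is expected to show a small decrease or none beyond the scatter, a 1.3-fold lower number from compound 2 to compound 3 (0.13 log units; within the scatter). Compound 3 is estimated at 250 nM, with a range from 80 nM to 800 nM.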

Compound 3, inhibition constant: 1430 nM
Compound 3: middle estimate off by 5.7-fold (0.76 log units), on the low side; measured number above the stated range.
By their numbers in this assay, from the lowest: compound 2; then compounds 1 and 3 (each within the scatter of the next).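

At this position the result turns on one ring carbon: cyclohexyl in place of cyclopentyl gives a 4.3-fold higher number from compound 2 to compound 3 (0.63 log units; beyond the scatter) in this assay and so undoes the gain that cyclopentyl showed over propyl. Cyclohexyl in place of propyl gives a 1.7-fold higher number from compound 1 to compound 3 (0.23 log units; within the scatter) and leaves those two groups unseparated. No evidence at hand accounts for this reversal. On these data alone, it remains open whether a cyclobutyl or a phenyl on this saturated chain carbon would track with cyclopentyl or with cyclohexyl.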